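The source may hold more compounds than are shown below. What is called first, only, known or untested is meant among the compounds shown, and "the series" means these compounds.

Measured in an assay on CHO cells for displacement of a labelled ligand from adenosine receptor A1 (Homo sapiens), read by scintillation counting, with a stated time of 120 min, tested at 10 uM; a lower number here means less inhibition, a higher number more inhibition at the concentration tested (going by the name of the read-out):

compound 1 `Nc1scc(CN2CCN(c3cccc(Cl)c3Cl)CC2)c1C(=O)c1ccc(Cl)cc1`: 2%
compound 2 `Nc1scc(CN2CCN(c3ccc(F)cc3Cl)CC2)c1C(=O)c1ccc(Cl)cc1`: 0%
compound 3 `Nc1scc(CN2CCN(c3ccc([N+](=O)[O-])cc3)CC2)c1C(=O)c1ccc(Cl)cc1`: 1%

All three numbers lie close together. Compound 3 stands second highest of the three, with compound 1 nearest: the step of a number 1 percentage points lower from compound 1 to compound 3 (within the scatter) is within the scatter, as is the step of a number 1 percentage points higher from compound 2 to compound 3 (within the scatter), so no order among the three can be read from these values.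

The next compound is compound 4 `Nc1scc(CN2CCN(c3cccc(C(F)(F)F)c3)CC2)c1C(=O)c1ccc(Cl)cc1`. It differs from compound 3 only in one place: 3-(trifluoromethyl)phenyl in place of 4-nitrophenyl on an amine nitrogen in a ring.

Every step recorded so far also exchanged the group on an amine nitrogen in a ring of the shared core, and none of them moved the read-out beyond the scatter: a number 2 percentage points lower from compound 1 to compound 2 (within the scatter), a number 1 percentage points lower from compound 1 to compound 3 (within the scatter) and a number 1 percentage points higher from compound 2 to compound 3 (within the scatter). On that basis the step to compound 4 is expected to be of the same kind, that is no change beyond the scatter: a number 1 percentage points higher from compound 3 to compound 4 (within the scatter). Compound 4 is therefore estimated at 2% in this assay, with a range from -6% to 12%.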

Compound 4, a percentage reported as inhibition, at one concentration (the size of the read-out at that concentration, not a potency): 0%
Estimate against measurement, compound 4: 2 percentage points above; the measured number falls inside the stated range.
By their numbers in this assay, from the lowest: compounds 2, 4, 3 and 1 (each within the scatter of the next).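

Notes on the group on the amine nitrogen in a ring, in this assay: 3-(trifluoromethyl)phenyl brings a fourth aryl group to this place, and no step to it leaves the scatter: a number 1 percentage points lower from compound 3 to compound 4 (within the scatter), no change at the digits printed from compound 2 to compound 4 (within the scatter) and a number 2 percentage points lower from compound 1 to compound 4 (within the scatter). The exchange also takes 4-nitrophenyl, with 2 hydrogen-bond acceptors, to a group with 0, and that difference in count does not separate compound 3 from compound 4 in this read-out. No supporting data bear on why these values sit so close together.

Every group shown at this place is a substituted phenyl ring, so the outcome with a benzyl group, a pyridine ring or a plain alkyl chain stays open. Also open, on these data alone, is whether a carboxylic acid or a longer chain elsewhere on the shared core would move the read-out beyond the scatter.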